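The source may report more compounds than this note shows. Statements on the series, on what has been measured and on what is new or still open speak of the compounds shown alone.

Compound 1, with the structure `CCc1nc(-c2ccc(OCCC(C)CCN3CCN(c4ccncc4)C3=O)cc2)no1`, was examined in an ADME assay on cells (Homo sapiens) for cytotoxicity; a higher number here means that more compound is tolerated, a lower number that less compound is tolerated. In this assay compound 1 gives > 25000 nM, which is a limit of the assay and not a measured number. Two other compounds built on the same core were examined alongside it. Compound 2, with the structure `O=C1N(Cc2ccc(COc3ccc(-c4ccc(Cl)cc4)cc3)cc2)CCN1c1ccncc1`, gives > 1250 nM in this assay, again only a limit. Compound 3, with the structure `CC(CCCN1CCN(c2ccncc2)C1=O)COc1ccc(-c2ccc(Cl)cc2)cc1`, gives > 25000 nM in this assay, also a limit. Compound 1 therefore sits among values that are all limits: the limit of > 25000 nM in this assay, at which 2 of the 3 values shown sit, while (the limit of > 1250 nM in this assay, at which 1 of the 3 values shown sits). No two of these compounds differ in just one place, so no measured step can be read from them.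

Compound 4, with the structure `CC(CCOc1ccc(-c2ccc(Cl)cc2)cc1)CCN1CCN(c2ccncc2)C1=O`, is the compound still to be measured. It differs from compound 1 in one place: 4-chlorophenyl in place of 5-ethyl-1,2,4-oxadiazol-3-yl on an aromatic carbon. The group that enters is the same 4-chlorophenyl group carried by compound 2 and compound 3. The step from compound 1 to compound 4 is expected to be a step that the limit leaves unreadable from compound 1 to compound 4, in other words nothing beyond the usual scatter. Compound 4 is expected to give 30000 nM, within a range from 12000 nM to 80000 nM, and most likely the assay will again report only a limit.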

Compound 4, half-maximal cytotoxic concentration: > 25000 nM
Compound 4 was reported as a limit; the forecaster's own chance of this, stated with the estimate: 80%; the middle value lies beyond the limit too.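

In this assay compound 4 gives > 25000 nM, which is a limit of the assay and not a measured number. Compound 1 gives > 25000 nM, also a limit, so no step can be read from compound 1 to compound 4. The compounds shown leave open how much of each is actually tolerated, and whether exchanging 5-ethyl-1,2,4-oxadiazol-3-yl for 4-chlorophenyl changes that at all.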